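Swapping the hydroxyphenyl for a methylpyridinyl on the core

The source may hold more compounds than are shown below. What is called first, only, known or untested is meant among the compounds shown, and "the series" means these compounds.

For the measured compounds named here, compound 2 `CC(C)c1cccc(C(C)C)c1NC(=O)Nc1nc2ccccc2n1-c1ccccc1O` gives 200 nM in an assay on isolated protein for displacement of a labelled ligand from acyl-CoA:cholesterol acyltransferase (Oryctolagus cuniculus) (a higher number here means a weaker inhibitor, a lower number a stronger inhibitor), the higher of the two numbers measured so far; compound 1 `CC(C)c1cccc(C(C)C)c1NC(=O)Nc1nc2ccccc2n1-c1ccccc1Cl` gives 18 nM. Going by the values given here, the one measured step, an 11-fold higher number from compound 1 to compound 2 (1.05 log units; beyond the scatter), is the only one touching this part of the molecule. Compound 3 `Cc1ncccc1-n1c(NC(=O)Nc2c(C(C)C)cccc2C(C)C)nc2ccccc21` carries 2-methylpyridin-3-yl in place of 2-hydroxyphenyl on an aromatic nitrogen, so the hydroxy leaves. Because an 11-fold higher number from compound 1 to compound 2 (1.05 log units; beyond the scatter) was large, the step to compound 3 is expected to run downward. On these data alone, the 2-methylpyridin-3-yl group is untested here, so for compound 3 only part of that span is expected and the estimated step is a 4.4-fold lower number from compound 2 to compound 3 (0.65 log units; beyond the scatter). Compound 3 is therefore estimated at 45 nM, within 15 nM to 150 nM.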

Compound 3, half-maximal inhibitory concentration: 100 nM
The estimate for compound 3 lay 2.2-fold (0.35 log units) below the measured number; low and high end bracket the measured number.
By their numbers in this assay, from the lowest: compound 1; then compounds 3 and 2 (each within the scatter of the next).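

In this assay the 2-methylpyridin-3-yl group cannot be told apart from the 2-hydroxyphenyl group at this position, with a 2.0-fold lower number from compound 2 to compound 3 (0.30 log units; within the scatter). Against the chloro compound the gap remains, with a 5.6-fold higher number from compound 1 to compound 3 (0.74 log units; beyond the scatter), so dropping the hydrogen-bond donor on this aryl group did not restore the number of compound 1. No evidence on the cause of either step is at hand.

On these data alone, whether a methoxy or an amine in place of the chloro on that phenyl ring would come closer to compound 1 stays open. So does the separate share of the ring nitrogen and the methyl in compound 3.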